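This account rests on a few compounds, and the source may have more. Where it says the series, first, only, none or still open, it means among the compounds named here.

Working notes on the thromboxane synthase series.

Compound 1 `O=C(O)CCCCCCc1cnccc1CCCNS(=O)(=O)c1ccc(Cl)cc1` is the reference point. In an assay on isolated protein for inhibition of Thromboxane-A synthase (Homo sapiens) (a lower number here means a stronger inhibitor, a higher number a weaker inhibitor), compound 1 gives 15 nM, the lowest of the two numbers obtained so far. Among the measured compounds shown here, compound 2 `O=C(O)CCCCCc1cnccc1CNS(=O)(=O)c1ccc(Cl)cc1` gives 66 nM in this assay, a higher number that lies beyond the usual scatter; compound 2 differs from compound 1 in more than one place, so no single step between the two is defined, and the pair shows only that a shortening on both sides of the shared core goes with a weaker result.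

Compound 3 `O=C(O)CCCCCc1cnccc1CCCNS(=O)(=O)c1ccc(Cl)cc1` is not yet measured. It keeps the three-carbon linker of compound 1 and differs from it in one place: carboxy in place of carboxymethyl on a saturated chain carbon, five bonds along the chain from an aromatic carbon. For the measured compounds named here, no measured pair isolates this change. Going by the values given here, since the only other compound with a carboxy-terminated chain of this length, compound 2, sits higher in this assay at 66 nM, a modest move toward weaker inhibition is expected for compound 3, of the size a 2.0-fold higher number from compound 1 to compound 3 (0.30 log units; within the scatter), though a step within the scatter would not surprise. The estimate for compound 3 in this assay is 30 nM, with a range from 12 nM to 80 nM.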

Compound 3, half-maximal inhibitory concentration: 100 nM
Compound 3: the middle estimate sits 3.3-fold (0.52 log units) below what was measured; measured number above the stated range.
By their numbers in this assay, from the lowest: compound 1; then compounds 2 and 3 (each within the scatter of the next).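

Carboxy in place of carboxymethyl on a saturated chain carbon, five bonds along the chain from an aromatic carbon, gives a 6.7-fold higher number from compound 1 to compound 3 (0.82 log units; beyond the scatter) in this assay, so a change on the acid-bearing chain alone, with the rest of compound 1 untouched, is enough to give a step beyond the scatter, which the earlier pair, differing on both sides of the shared core, could not show. Compound 2 at 66 nM and compound 3 at 100 nM lie within the scatter of each other, so these values show no separation between the two despite the difference in the chain that carries the sulfonamide. No supporting measurement bears on why this single change shifts the number.

From the compounds shown here alone, this is one step at one position, so it sets no trend in chain length, and whether a longer chain than that of compound 1 would give a lower or a higher number remains open. Equally open, going by these compounds, is how the chain of compound 1 would read with a primary amide, a methyl ester or a tetrazole in place of the carboxylic acid at its end.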